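Swapping 3,5-difluorophenyl for 3-(methylsulfonyl)phenyl on the shared core

The source may hold more compounds than are shown below. What is called first, only, known or untested is meant among the compounds shown, and "the series" means these compounds.

Of the compounds shown here, two sharing one core have been measured so far. Among the compounds with values here, in a physicochemical assay for solubility, read by HPLC, using the shake flask method, in phosphate buffer, with a stated time of 20 h, at pH 6.5 (a lower number here means a less soluble compound, a higher number a more soluble compound), compound 1 (`CN1CCN(C2CCN(c3nccc4[nH]c(-c5ccc(F)c(C(F)(F)F)c5)nc34)CC2)CC1`) gives 195000 nM, and compound 2 (`CN1CCN(C2CCN(c3nccc4[nH]c(-c5cc(F)cc(F)c5)nc34)CC2)CC1`) gives 200000 nM, so compound 2 stands level with the only other number available. Placing 3,5-difluorophenyl where 4-fluoro-3-(trifluoromethyl)phenyl had been gave a 1.0-fold higher number from compound 1 to compound 2 (0.01 log units; within the scatter).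

The next structure is compound 3 (`CN1CCN(C2CCN(c3nccc4[nH]c(-c5cccc(S(C)(=O)=O)c5)nc34)CC2)CC1`), which carries 3-(methylsulfonyl)phenyl in place of 3,5-difluorophenyl on an aromatic carbon of the five-membered aromatic ring, between two ring nitrogen atoms: 3-(methylsulfonyl)phenyl in place of 3,5-difluorophenyl on an aromatic carbon. Within the data shown here, only one measured step bears on this change, the exchange at the same carbon that gave a 1.0-fold higher number from compound 1 to compound 2 (0.01 log units; within the scatter). Among the measured compounds shown here, that evidence is thin, since both groups measured there carry fluorine and no measured compound carries 3-(methylsulfonyl)phenyl. On the strength of that one step, no shift beyond the scatter is expected in this assay, in either direction. The expected step is no change at the digits printed from compound 2 to compound 3 (within the scatter). For compound 3 the estimated value is 200000 nM, with an expected range from 110000 nM to 300000 nM.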

Compound 3, solubility: 190000 nM
Compound 3: middle estimate off by 1.1-fold (0.02 log units), on the high side; the range from low to high includes it.
By their numbers in this assay, from the lowest: compounds 3, 1 and 2 (each within the scatter of the next).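

In this assay, the exchange on the aromatic carbon of the five-membered aromatic ring, between two ring nitrogen atoms, now extends to a group without fluorine, and the three numbers stand level. 3-(Methylsulfonyl)phenyl, with 2 hydrogen-bond acceptors and 2 double bonds outside aromatic rings, in place of 3,5-difluorophenyl, with 0 hydrogen-bond acceptors, gave a small step (a 1.1-fold lower number from compound 2 to compound 3 (0.02 log units; within the scatter)), and the same group in place of 4-fluoro-3-(trifluoromethyl)phenyl gave another (a 1.0-fold lower number from compound 1 to compound 3 (0.01 log units; within the scatter)), so this position has now taken three different substituted phenyl groups with no step beyond the scatter. Nothing measured here explains why these numbers stand level.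

On these data alone, all three compounds keep a phenyl ring on this carbon and the same remainder of the shared core, so it remains open whether the level numbers would hold with a carboxylic acid or an amine on that phenyl ring, or with a saturated ring or a short alkyl chain in its place. The compounds shown also leave open whether any change elsewhere on the shared core, such as replacing the N-methyl group, would move the number in this assay beyond the scatter.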